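Methyl on the Sulfonyl Ring of a Thioester Probe

A few compounds are considered here, and "the series" means these few. Any claim that something is new, unique, unknown or untested is made for them only; others in the source may bear on it.

Measured compounds:
Compound 1, `CC(=O)SCC(=O)c1ccc(NS(=O)(=O)c2ccccc2)cc1`: 15400 nM
Compound 2, `CC(=O)SCC(=O)c1ccc(NS(=O)(=O)c2ccc(C(F)(F)F)cc2)cc1`: "not determined" (no result reported)

Compound 1 carries a thioacetate chain on a ketone, joined to a sulfonamide that bears an unsubstituted phenyl ring. In a functional assay on HCT-116 cells (Homo sapiens) for cytotoxicity (on this read-out higher numbers stand for an effect only at larger amounts of compound and lower numbers for an effect already at smaller amounts), compound 1 gives 15400 nM. Going by the values given here, this is the only number in the set, so compound 1 stands alone as the reference point. Compound 2 adds a trifluoromethyl group to the sulfonyl ring, but no result was reported for it, so it offers no comparison.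

Compound 3, `CC(=O)SCC(=O)c1ccc(NS(=O)(=O)c2ccc(C)cc2)cc1`, is not yet measured. It differs from compound 1 by methyl in place of hydrogen on an aromatic carbon. A single carbon enters on the outer ring of the sulfonamide; nothing else in the molecule changes.

Among the compounds with values here, no step between two measured compounds is available, so there is nothing in the data to show how such a small addition shifts the read-out. Without that guide, the expectation is a step of a 1.0-fold lower number from compound 1 to compound 3 (0.01 log units; within the scatter), that is, none beyond the usual scatter. Compound 3 is therefore expected to give about 15000 nM in this assay, within the range 5000 nM to 45000 nM.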

Compound 3, half-maximal effective concentration: 6500 nM
For compound 3 the middle estimate is 2.3-fold (0.36 log units) above the measured one; measured number inside the range.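

The outer ring of the sulfonamide responds to even a very small change: in this assay, methyl in place of hydrogen on an aromatic carbon, para to a large group, gives a 2.4-fold lower number from compound 1 to compound 3 (0.37 log units; beyond the scatter). This first readable step shows that the position is not silent, since the change from phenyl to 4-methylphenyl leaves the rest of the molecule untouched and still moves the read-out beyond the usual scatter, though only modestly, towards an effect at smaller amounts of compound. Nothing at hand explains why one added carbon has this effect.

The step to the trifluoromethyl compound, compound 2, cannot be read, as it has no reported result. A single methyl group also cannot show whether a different group on this ring, such as a chlorine atom, a methoxy group or a longer chain like ethyl, would push the number further down, leave it unchanged or raise it again.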